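Methoxy for chloro and a cytotoxicity limit

The compounds below may be only part of what the source reports. "The series", "measured", "known", "first", "only" and "open" are said of these compounds alone.

Three measured compounds share a core, and the fourth is unmeasured. In an ADME assay on MT4 cells (Homo sapiens) for cytotoxicity, read by MTT assay (on this read-out higher numbers stand for lower toxicity in this test and lower numbers for higher toxicity in this test), compound 2 `Cc1ccccc1NC(=O)CSc1nccn1-c1ccc(Cl)cc1` gives 160000 nM and compound 3 `Cc1ccc(NC(=O)CSc2nccn2-c2ccc(Cl)cc2)c(Br)c1` gives 221000 nM; the two cores differ by 2-bromo-4-methylphenyl in place of 2-methylphenyl on an amide-type nitrogen, and the step is a 1.4-fold higher number from compound 2 to compound 3 (0.14 log units; within the scatter). Compound 1 `COc1ccc(-n2ccnc2SCC(=O)Nc2ccccc2C)cc1` reaches only a limit of this assay, > 353000 nM, a limit at which (the limit of > 353000 nM in this assay, at which 1 of the 3 values shown sits). The change from compound 2 to compound 1 is methoxy in place of chloro on an aromatic carbon, and the step is an at least 2.2-fold higher number from compound 2 to compound 1 (0.34 log units; beyond the scatter). Compound 4 `COc1ccc(-n2ccnc2SCC(=O)Nc2ccc(C)cc2Br)cc1` differs from compound 3 by methoxy in place of chloro on an aromatic carbon, the same change, made at the same place. For compound 4 a step of a 2.3-fold higher number from compound 3 to compound 4 (0.35 log units; beyond the scatter) is expected in this assay, resting on the earlier step of an at least 2.2-fold higher number from compound 2 to compound 1 (0.34 log units; beyond the scatter). Compound 4 is therefore estimated at 500000 nM, likely again reported only as a limit.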

Compound 4, half-maximal cytotoxic concentration: 25800 nM
The estimate for compound 4 lay 19-fold (1.29 log units) above the measured number; measured number below the stated range.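

In this assay the change from 4-chlorophenyl to 4-methoxyphenyl did not carry from one core to the other, and on the core of compound 3 it gave (an 8.6-fold lower number from compound 3 to compound 4 (0.93 log units; beyond the scatter)), against the rise seen on the other core: the same change on two cores in this assay, an at least 2.2-fold higher number (0.34 log units; beyond the scatter) from compound 2 to compound 1 and an 8.6-fold lower number (0.93 log units; beyond the scatter) from compound 3 to compound 4, at least 18-fold (1.27 log units) apart, beyond the scatter of two such steps.
The 2-bromo-4-methylphenyl swap likewise depended on the group at the other end, giving (an at least 13-fold lower number from compound 1 to compound 4 (1.13 log units; beyond the scatter)) with methoxy in place: the same change on two cores in this assay, a 1.4-fold higher number (0.14 log units; within the scatter) from compound 2 to compound 3 and an at least 13-fold lower number (1.13 log units; beyond the scatter) from compound 1 to compound 4, at least 18-fold (1.27 log units) apart, beyond the scatter of two such steps.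
Compound 1 gives > 353000 nM, which is a limit, and two cores show neither why these steps part nor how the change would run on a third core.

The compounds shown leave open whether the bromo or the methyl of the 2-bromo-4-methylphenyl group alone goes with the lower number of compound 4. They also leave open how fluoro or ethoxy in place of methoxy would read on either core.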